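A few compounds are considered here, and "the series" means these few. Any claim that something is new, unique, unknown or untested is made for them only; others in the source may bear on it.

Measured so far in a functional assay on MDA-MB-231 cells (Homo sapiens) for inhibition, read by MTT assay, with a stated time of 72 h; a higher number here means a weaker inhibitor, a lower number a stronger inhibitor:
compound 1, `O=C(CSc1nc(Nc2ccccc2)c2ccccc2n1)Nc1ccc(Br)cc1`: 11500 nM
compound 2, `C=CC(=O)Nc1cccc(NC(=O)CSc2nc(Nc3ccccc3C)c3ccccc3n2)c1`: 20400 nM

Both compounds share the same core and differ only in the group carried on the ring nitrogen and in the amide-bearing aryl part. Compound 2 stands at one end of the two numbers in this assay, but compound 1 lies close enough that the gap between them falls within the usual scatter of repeated measurements, so the two cannot be told apart on these data.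

Compound 3, `C=CC(=O)Nc1cccc(NC(=O)CSc2nc(Nc3ccc(Cl)cc3Cl)c3ccccc3n2)c1`, has not yet been tested in this assay. Its relation to compound 2 is a single change: 2,4-dichlorophenyl in place of 2-methylphenyl on a nitrogen on an aromatic ring. Among the measured compounds shown here, no measured pair carries this change, so there is no step of this kind to lean on. For the measured compounds named here, with only two numbers in hand, neither of which separates from the other, the expected step from compound 2 to compound 3 is a 1.4-fold lower number from compound 2 to compound 3 (0.13 log units; within the scatter), in either direction, and not expected to exceed the scatter. Compound 3 is thus estimated at 15000 nM in this assay, with a range from 5000 nM to 45000 nM.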

Compound 3, half-maximal inhibitory concentration: 23100 nM
For compound 3 the middle estimate is 1.5-fold (0.19 log units) below the measured one; low and high end bracket the measured number.
By their numbers in this assay, from the lowest: compounds 1, 2 and 3 (each within the scatter of the next).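

In this assay, among the compounds shown here, the series now has its only step that differs in one place: a 1.1-fold higher number from compound 2 to compound 3 (0.05 log units; within the scatter) for 2,4-dichlorophenyl in place of 2-methylphenyl on a nitrogen on an aromatic ring. This change brings in two chlorine atoms and removes the methyl group while the six-membered aromatic ring of carbon only, the count of hydrogen-bond donors and acceptors and the absence of net charge all stay the same, and on this one pair the two aryl groups cannot be told apart at this position. No measured property of either group bears on this result.

Still open, from the compounds shown here alone, is whether any group on this nitrogen can move the number beyond the scatter, as both groups in this pair are carbon-only aromatic rings, and a pyridine ring, a morpholine or a phenyl ring carrying a carboxylic acid would probe a different kind of substituent here. Also open, going by these compounds, is whether the same change reads alike when the amide-bearing aryl part is that of compound 1 rather than that of compound 2.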